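The source may report more compounds than this note shows. Statements on the series, on what has been measured and on what is new or still open speak of the compounds shown alone.

In an ADME assay on MT4 cells (Homo sapiens) for activation, read by MTT assay (on this read-out lower numbers stand for higher toxicity in this test and higher numbers for lower toxicity in this test), compound 1 (`CCC(C)Sc1nc(Cc2c(F)cccc2Cl)cc(=O)[nH]1`) gives > 76000 nM, which is a limit of the assay. Compound 2 (`CCC(C)Sc1nc(Cc2c(F)cccc2Cl)c(C)c(=O)[nH]1`) gives > 73000 nM, also a limit and no number. Compound 3 (`CCCCSc1nc(Cc2c(F)cccc2Cl)c(C)c(=O)[nH]1`) gives > 73000 nM, again a limit. Compound 4 (`CCC(C)Sc1nc(C(C)c2c(F)cccc2Cl)c(C)c(=O)[nH]1`) departs from compound 2 by methyl in place of hydrogen on a saturated chain carbon bound to two aromatic carbons. Within the data shown here, two measured steps bear on this: a step that the two limits leave unreadable from compound 1 to compound 2, also methyl in place of hydrogen but on an aromatic carbon, and a step that the two limits leave unreadable from compound 2 to compound 3. Neither gives a size to carry over, so no step beyond the scatter is expected in this assay, in either direction. The expected step is an at least 1.0-fold lower number from compound 2 to compound 4 (0.01 log units; that floor lies within the scatter). Compound 4 is estimated at 70000 nM, with an expected range of 30000 nM to 100000 nM.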

Compound 4, half-maximal cytotoxic concentration: > 1500 nM
Compound 4: no number, only a limit; the forecaster's own chance of this, stated with the estimate: 80%; the middle value lies beyond the limit too.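

Among these compounds, compound 2 and compound 4 both stand as limits in this assay, and no step between them can be read. The compounds shown leave open whether methyl in place of hydrogen on this saturated chain carbon shifts the read-out at all.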